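The compounds below may be only part of what the source reports. "The series", "measured", "known", "first", "only" and "open" are said of these compounds alone.

Working notes on the series. Compound 3 `Cc1ccc(-c2ccccc2OCC2=NCCN2)s1` stands at a limit: in a functional assay for activation of Alpha-1B adrenergic receptor (Homo sapiens), read by calcium flux (a lower number here means that less compound is needed, a higher number that more compound is needed for the effect), compound 3 gives < 100000 nM, which is a limit of the assay and not a number (the limit of < 100000 nM in this assay, at which 1 of the 3 values shown sits). Compound 1 `c1ccc(-c2ccns2)c(OCC2=NCCN2)c1` gives 12.6 nM in this assay, and compound 2 `c1ccc(-c2nccs2)c(OCC2=NCCN2)c1` gives 20 nM; the step of a 1.6-fold higher number from compound 1 to compound 2 (0.20 log units; within the scatter) lies within the scatter. The steps a step that the limit leaves unreadable from compound 1 to compound 3 and a step that the limit leaves unreadable from compound 2 to compound 3 cannot be sized, as compound 3 sits at the limit.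

Compound 4 `Cc1cc(-c2ccccc2OCC2=NCCN2)sn1` differs from compound 3 by 3-methyl-1,2-thiazol-5-yl in place of 5-methylthiophen-2-yl on an aromatic carbon. The entering ring is the ring type carried by compound 1, with a methyl added. Only the unreadable steps from compound 1 and compound 2 to compound 3 bear on the change, so the size of the step cannot be taken from a measured pair. Since compound 1 gives 12.6 nM with the same ring type, compound 4 is expected to move back toward that range, an expected step that the limit leaves unreadable from compound 3 to compound 4, while the added methyl leaves the size uncertain. Compound 4 is therefore estimated at 100 nM in this assay, expected between 10 nM and 5000 nM.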

Compound 4, half-maximal effective concentration: < 100000 nM
Compound 4 gave a limit, no number (the forecaster's own chance of this, stated with the estimate: 20%); the middle value is on the limit's open side.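

Compound 4 gives < 100000 nM, a limit and not a number, so no step from compound 1, compound 2 or compound 3 to compound 4 can be read: the limit of < 100000 nM in this assay, at which 2 of the 4 values shown sit.

The compounds shown leave open how large the change is with methyl in place of hydrogen, and how compound 3 and compound 4 stand to each other.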